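A few compounds are considered here, and "the series" means these few. Any claim that something is new, unique, unknown or untested is made for them only; others in the source may bear on it.

Among the measured compounds shown here, compound 1 `c1ccc2c(c1)CCC2CCCN1CCN(c2cccc3c2OCCO3)CC1` gives 0.16 mg/kg in a functional assay on the whole organism for antagonist activity, with Rattus norvegicus as the target (a lower number here means that less compound is needed, a higher number that more compound is needed for the effect), the lower of the two numbers measured so far. Compound 2 `Clc1cccc2c1CC2CN1CCN(c2cccc3c2OCCO3)CC1` gives 0.63 mg/kg, a higher number beyond the scatter. Compound 3 `Clc1cccc2c1CC2CCCN1CCN(c2cccc3c2OCCO3)CC1` is not yet measured. It differs from compound 1 in one place: a group of 9 heavy atoms (8 carbon, 1 chlorine; one four-membered non-aromatic ring of carbon only, one six-membered aromatic ring of carbon only) in place of a group of 9 heavy atoms (9 carbon; one five-membered non-aromatic ring of carbon only, one six-membered aromatic ring of carbon only), on a saturated chain carbon, three bonds along the chain from an amine nitrogen in a ring. For the measured compounds named here, no measured pair shows this change alone, so its size cannot be read from the data. The step of a 1.9-fold higher number from compound 1 to compound 3 (0.27 log units; within the scatter) is expected to be small, likely within the scatter, if anything toward a higher number. The estimate for compound 3 is 0.3 mg/kg, in the range 0.1 mg/kg to 1 mg/kg.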

Compound 3, minimum effective dose: 0.63 mg/kg
Beside the measured number, compound 3's estimate is 2.1-fold (0.32 log units) below it; the range from low to high includes it.
By their numbers in this assay, from the lowest: compound 1; then compounds 2 and 3 (each within the scatter of the next).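

Replacing the 2,3-dihydro-1H-inden-1-yl group with the chlorine-bearing group with the four-membered ring gives, in this assay,  a 3.9-fold higher number from compound 1 to compound 3 (0.60 log units; beyond the scatter). Among the compounds shown here, this is the first measured sign that this place on the chain responds to the group it carries, with more compound needed after the change. No available evidence explains the step.

The change alters ring size and adds chlorine together, so the two cannot be separated. As far as these compounds go, the effect of a chlorine on the 2,3-dihydro-1H-inden-1-yl group, or of fluorine in its place, remains open.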